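Cytotoxicity limits in a sulfonamide series, toward compound 4

The compounds below may be only part of what the source reports. "The series", "measured", "known", "first", "only" and "open" are said of these compounds alone.

Measured in an ADME assay on HCT-116 cells (Homo sapiens) for cytotoxicity, read by CellTiter-Glo, with a stated time of 72 h; a higher number here means a weaker inhibitor, a lower number a stronger inhibitor:
compound 1 `CC1CCN(C2CCN(S(=O)(=O)c3cnc(Cl)s3)CC2)CC1` — a limit of the assay, > 10000 nM
compound 2 `CCCOc1ccc(S(=O)(=O)N2CCC(N3CCC(C)CC3)CC2)cc1` — a limit of the assay, > 5000 nM
compound 3 `CC1CCN(C2CCN(S(=O)(=O)c3sc(Cl)nc3C3CC3)CC2)CC1` — a limit of the assay, > 10000 nM

For the measured compounds named here, compound 1 stands only at a limit in this assay, and the two other values shown are limits as well, so no compound in the set has a readable number. Going by the values given here, the one step between compounds differing in a single place, cyclopropyl in place of hydrogen on an aromatic carbon, is a step that the two limits leave unreadable from compound 1 to compound 3; the two limits leave its size unreadable. What the series shows is summarised by the limit of > 10000 nM in this assay, at which 2 of the 3 values shown sit, and by the limit of > 5000 nM in this assay, at which 1 of the 3 values shown sits.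

Compound 4 `CC1CCN(C2CCN(S(=O)(=O)c3cncc(Br)c3)CC2)CC1` differs from compound 1 by 5-bromopyridin-3-yl in place of 2-chloro-1,3-thiazol-5-yl on a sulfonyl sulfur. Among the compounds with values here, no measured step bears on this change, and every value in the set sits at a limit, so no step beyond the scatter is expected in this assay; the step from compound 1 to compound 4 is estimated as a step that the limit leaves unreadable from compound 1 to compound 4. Compound 4 is expected to give about 15000 nM in this assay, within 5000 nM to 50000 nM, most likely reported again only as a limit.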

Compound 4, half-maximal inhibitory concentration: > 10000 nM
Compound 4 was reported as a limit (the forecaster's own chance of this, stated with the estimate: 80%); the middle value lies beyond the limit too.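

Compound 1 and compound 4 stand only as limits in this assay and so no new step can be read between them. The compounds shown leave open whether any group on the sulfonyl sulfur would give a readable value.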